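The source may report more compounds than this note shows. Statements on the series, on what has been measured and on what is new or still open speak of the compounds shown alone.

Measured in an ADME assay on HepG2 cells (Homo sapiens) for cytotoxicity, in the presence of a further agent that is not named here; a higher number here means a weaker inhibitor, a lower number a stronger inhibitor (both values are limits):
compound 1 `CN(Cc1ccccc1)C(=O)c1nc(Cc2ccccc2C(F)(F)F)n(C)c(=O)c1O` gives > 100000 nM (limit)
compound 2 `Cn1c(Cc2ccccc2C(F)(F)F)nc(C(=O)CCc2ccccc2)c(O)c1=O` gives > 100000 nM (limit)

In this assay compound 2 gives only a limit (> 100000 nM) and no number. Within the data shown here, the one measured step (a step that the two limits leave unreadable from compound 1 to compound 2) has no readable size, and the evidence so far is the limit of > 100000 nM in this assay, at which 2 of the 2 values shown sit, alone. Compound 3 `Cn1c(Cc2ccccc2C(F)(F)F)nc(C(=O)NCc2ccccn2)c(O)c1=O` follows from compound 2 by ((pyridin-2-yl)methyl)amino in place of phenethyl on a carbonyl carbon on a carbonyl carbon. From the limit of compound 2 (> 100000 nM) no step beyond the scatter is expected in this assay and the estimated step reads a number no higher from compound 2 to compound 3 (the limit leaves the size open) (an expectation only). For compound 3 the expected value is 100000 nM (estimated range 30000 nM to 200000 nM), and another limit is likely.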

Compound 3, half-maximal inhibitory concentration: > 100000 nM
Compound 3: only a limit was reported; the forecaster's own chance of this, stated with the estimate: 85%; the middle value lies on the limit itself.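

In this assay, among these compounds, compound 3 gives > 100000 nM, a limit, so no step among compound 1, compound 2 and compound 3 can be read. The compounds shown leave open whether the groups on the carbonyl carbon differ at all in this read-out.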